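A few compounds are considered here, and "the series" means these few. Any claim that something is new, unique, unknown or untested is made for them only; others in the source may bear on it.

Compound 1 `c1ccc(Cn2cc(COc3ccccc3)nn2)cc1` gives 10600 nM in an assay on isolated protein for inhibition of Aromatase (Homo sapiens), read by fluorescence and colorimetric assay, with a stated time of 30 min; a lower number here means a stronger inhibitor, a higher number a weaker inhibitor. Compound 2 `COc1ccc(OCc2cn(Cc3ccccc3)nn2)cc1` gives 17300 nM in this assay.

Within the data shown here, only these two numbers exist, and the single step between them, a 1.6-fold higher number from compound 1 to compound 2 (0.21 log units; within the scatter), lies within the scatter, so compound 2 and compound 1 cannot be told apart on potency. Compound 3 `c1ccc(Cn2cc(COc3ccc(-c4ccccc4)cc3)nn2)cc1` differs from compound 2 by phenyl in place of methoxy on an aromatic carbon. Among the measured compounds shown here, the one step that touches the same position, a 1.6-fold higher number from compound 1 to compound 2 (0.21 log units; within the scatter), was small; no measured step involves a phenyl, so the data offer no basis for a large change. Compound 3 is therefore expected near compound 2, with a 1.3-fold lower number from compound 2 to compound 3 (0.12 log units; within the scatter), at an estimated 13000 nM within 4000 nM to 40000 nM.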

Compound 3, half-maximal inhibitory concentration: 10700 nM
For compound 3 the middle estimate is 1.2-fold (0.08 log units) above the measured one, and the stated range covers the measured number.
By their numbers in this assay, from the lowest: compounds 1, 3 and 2 (each within the scatter of the next).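

Phenyl in place of methoxy on this aromatic carbon brings in a six-membered aromatic ring, yet the result is a 1.6-fold lower number from compound 2 to compound 3 (0.21 log units; within the scatter), and phenyl in place of hydrogen gives a 1.0-fold higher number from compound 1 to compound 3 (0.00 log units; within the scatter). In this assay hydrogen, methoxy and phenyl at this place therefore cannot be told apart, even with the added ring. Nothing available explains why the numbers stay level.

As far as these compounds go, whether an amine or a carboxylic acid at this place would shift the number remains open, as does whether any group here can move it beyond the scatter of these three compounds.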